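A few compounds are considered here, and "the series" means these few. Any claim that something is new, unique, unknown or untested is made for them only; others in the source may bear on it.

Measured so far:
Compound 1, `Oc1ccccc1-c1cc(-c2ccccc2)cc(-c2ccccc2O)n1`, gives 37300 nM.
Compound 2, `Oc1cccc(-c2cc(-c3ccccc3)cc(-c3ccsc3)n2)c1`, gives 12100 nM.

Both numbers come from a functional assay on MDA-MB-231 cells (Homo sapiens) for cytotoxicity, read by ELISA, with a stated time of 2 days; on this read-out higher numbers stand for weaker inhibition and lower numbers for stronger inhibition. Compound 2 stands lowest of the two numbers; its nearest neighbour is compound 1, whose number is higher by a gap beyond the usual scatter. The unmeasured compound 3, `Oc1cccc(-c2cc(-c3ccccc3)cc(-c3cccc(O)c3)n2)c1`, differs from compound 2 in one place: 3-hydroxyphenyl in place of thiophen-3-yl on an aromatic carbon. Among the compounds with values here, no two measured compounds differ in only one place, so no step of this kind has been seen here. Within the data shown here, the only hint is that compound 1, which carries two hydroxyphenyl groups on the shared core, gave 37300 nM, the higher of the two numbers. On that basis a small step toward weaker inhibition is expected for compound 3, which may well stay within the scatter, and the estimated step is a 1.3-fold higher number from compound 2 to compound 3 (0.12 log units; within the scatter). Compound 3 is therefore expected to give about 16000 nM, in a range from 5000 nM to 50000 nM.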

Compound 3, half-maximal inhibitory concentration: 12800 nM
Compound 3: the middle estimate sits 1.3-fold (0.10 log units) above what was measured, and the stated range covers the measured number.
By their numbers in this assay, from the lowest: compounds 2 and 3 (each within the scatter of the next); then compound 1.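

Replacing thiophen-3-yl with 3-hydroxyphenyl on the aromatic carbon next to the ring nitrogen gives a 1.1-fold higher number from compound 2 to compound 3 (0.02 log units; within the scatter) in this assay and stays within the scatter. Within the data shown here, this is the first comparison here of two compounds that differ in only one place, and it shows that this position accepts either aromatic ring with no readable change in the number, even though the hydrogen-bond donor of 3-hydroxyphenyl enters with the swap. No independent measurement bears on this result.

As far as these compounds go, only these two aromatic rings are compared at this position, so it remains open whether an amine, a carboxylic acid or a longer alkyl chain there would shift the number beyond the scatter. From the compounds shown here alone, it also remains open whether a methoxy group in place of the hydroxyl would change anything.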